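The source may hold more compounds than are shown below. What is called first, only, known or untested is meant among the compounds shown, and "the series" means these compounds.

Compound 2 (`O=c1oc2ccccc2c(=O)n1-c1ccc(F)cc1F`) reached only a limit in an ADME assay on RAW264.7 cells (Mus musculus) for cytotoxicity, read by MTT assay, with a stated time of 24 h (on this read-out higher numbers stand for lower toxicity in this test and lower numbers for higher toxicity in this test), reported as > 40000 nM. Its close relative compound 1 (`O=c1oc2ccccc2c(=O)n1-c1ccc(Cl)cc1F`) gives 26500 nM in this assay. Between them the step was an at least 1.5-fold higher number from compound 1 to compound 2 (0.17 log units; that floor lies within the scatter), where fluoro replaced chloro, a step capped by the limit of > 40000 nM in this assay, at which 1 of the 2 values shown sits. Compound 3 (`O=c1oc2ccccc2c(=O)n1-c1ccc(I)cc1F`) carries iodo in place of fluoro on an aromatic carbon. For the measured compounds named here, that swap runs in the opposite sense to the single measured step, so a somewhat lower number is expected, with a size of an at least 2.0-fold lower number from compound 2 to compound 3 (0.30 log units; that floor lies within the scatter). Compound 3 is therefore estimated at 20000 nM, with a likely range from 8000 nM to 45000 nM.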

Compound 3, half-maximal cytotoxic concentration: 23600 nM
The estimate for compound 3 lay 1.2-fold (0.07 log units) below the measured number, and the stated range covers the measured number.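

Iodo in place of chloro gives a 1.1-fold lower number from compound 1 to compound 3 (0.05 log units; within the scatter), so chloro and iodo at this position cannot be told apart in this assay. Iodo in place of fluoro gives an at least 1.6-fold lower number from compound 2 to compound 3 (0.22 log units; that floor lies within the scatter), so even this swap is not shown to go beyond the usual scatter. That step is only a floor because compound 2 is read against a limit: the limit of > 40000 nM in this assay, at which 1 of the 3 values shown sits.

The compounds shown leave open whether any change at this position moves the number clearly. They also leave open how a group other than a halogen, such as an amine or a carboxylic acid, would read here.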